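Estimating a side-group swap starting from compound 3

A few compounds are considered here, and "the series" means these few. Any claim that something is new, unique, unknown or untested is made for them only; others in the source may bear on it.

In a physicochemical assay for solubility, read by chemiluminescence, measured as kinetic solubility (a lower number here means a less soluble compound, a higher number a more soluble compound), compound 1 (`O=C([C@@H]1CCCN1)N1CCC2(CCN(c3nccc(NCc4ccc(Cl)cc4Cl)n3)CC2)C1`) gives 165 ug/mL while compound 2 (`O=C([C@@H]1CCCCN1)N1CCC2(CCN(c3nccc(NCc4ccc(Cl)cc4Cl)n3)CC2)C1`) gives 170 ug/mL and compound 3 (`O=C(C1CCCNC1)N1CCC2(CCN(c3nccc(NCc4ccc(Cl)cc4Cl)n3)CC2)C1`) gives 186 ug/mL on the same scale. Compound 3 therefore stands level with the other two, within the scatter. Compound 4 (`Clc1ccc(CNc2ccnc(N3CCC4(CCN(C[C@H]5CCCN5)C4)CC3)n2)c(Cl)c1`) carries (pyrrolidin-2-yl)methyl in place of (piperidin-3-yl)carbonyl on an amine nitrogen in a ring. Three measured ring swaps bear on this: a 1.0-fold higher number from compound 1 to compound 2 (0.01 log units; within the scatter) and a 1.1-fold higher number from compound 1 to compound 3 (0.05 log units; within the scatter) and a 1.1-fold higher number from compound 2 to compound 3 (0.04 log units; within the scatter) all stayed within the scatter. From the compounds shown here alone, none of them removes the carbonyl, so that part remains untested. No step beyond the scatter is therefore expected in this assay, and the expected step is a 1.0-fold lower number from compound 3 to compound 4 (0.01 log units; within the scatter) with real uncertainty around it. Compound 4 is estimated at 180 ug/mL (range 100 ug/mL to 300 ug/mL).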

Compound 4, solubility: 16 ug/mL
The estimate for compound 4 lay 11-fold (1.05 log units) above the measured number; measured number below the stated range.
By their numbers in this assay, from the lowest: compound 4; then compounds 1, 2 and 3 (each within the scatter of the next).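

Changing the ring on the carbonyl stayed within the scatter in this assay but replacing the carbonyl-linked group on this amine nitrogen with (pyrrolidin-2-yl)methyl brings a 12-fold lower number from compound 3 to compound 4 (1.07 log units; beyond the scatter) and an 11-fold lower number from compound 2 to compound 4 (1.03 log units; beyond the scatter) and a 10-fold lower number from compound 1 to compound 4 (1.01 log units; beyond the scatter) as the result. The last of these steps keeps the pyrrolidin-2-yl ring, so at this position the large drop goes with exchanging the carbonyl for a methyl link, and ring size alone does not account for it. No measurement here offers an explanation for the drop.

From the compounds shown here alone, whether (piperidin-3-yl)methyl on the same nitrogen would match compound 4 remains open. So does the outcome with a sulfonyl link or a longer chain.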